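The compounds below may be only part of what the source reports. "The series", "measured", "known", "first", "only" and "open" are said of these compounds alone.

Three compounds share one core and differ only in the aryl group attached to it. Compound 1 `O=S(=O)(c1cccc(F)c1)c1cnc2c(F)cccc2c1-c1cccc(Cl)c1` gives 0.56 mL/min in an ADME assay on microsomes from liver (Homo sapiens) for metabolic stability, tested at 2.5 uM; on this read-out higher numbers stand for fast clearance and lower numbers for slow clearance; compound 2 `O=S(=O)(c1cccc(F)c1)c1cnc2c(F)cccc2c1-c1ccc(Cl)cc1` gives 0.62 mL/min; and compound 3 `O=S(=O)(c1cccc(F)c1)c1cnc2c(F)cccc2c1-c1ccc(F)cc1` gives 0.19 mL/min. Compound 3 thus holds the lowest of the three numbers: a 2.9-fold lower number from compound 1 to compound 3 (0.47 log units; beyond the scatter) and a 3.3-fold lower number from compound 2 to compound 3 (0.51 log units; beyond the scatter), whereas a 1.1-fold higher number from compound 1 to compound 2 (0.04 log units; within the scatter). Compound 4 `COc1cccc(-c2c(S(=O)(=O)c3cccc(F)c3)cnc3c(F)cccc23)c1` has not yet been measured in this assay. It differs from compound 3 in one place: 3-methoxyphenyl in place of 4-fluorophenyl on an aromatic carbon. Among the measured compounds shown here, no measured step involves a methoxy group, so the only guidance comes from the two steps that reach compound 3, both of modest size and both beyond the scatter: in each, exchanging another substituted phenyl for the 4-fluorophenyl lowered the number. Moving away from the 4-fluorophenyl is therefore expected to raise the number, by a modest step, though a result within the scatter cannot be excluded. Compound 4 is expected to give about 0.5 mL/min, in a range from 0.2 mL/min to 1.2 mL/min. The expected step is a 2.6-fold higher number from compound 3 to compound 4 (0.42 log units; beyond the scatter).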

Compound 4, intrinsic clearance in a liver preparation (reported as CLH), per the amount of preparation that the assay uses: 2.6 mL/min
The estimate for compound 4 lay 5.2-fold (0.72 log units) below the measured number; the whole stated range lies below it.
By their numbers in this assay, from the lowest: compound 3; then compounds 1 and 2 (each within the scatter of the next); then compound 4.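

In this assay, the aryl position on the shared core proves far more sensitive than the halogen-bearing compounds alone suggested: compound 4 has the highest number of the four, and the step from the 4-fluorophenyl group is large (a 14-fold higher number from compound 3 to compound 4 (1.14 log units; beyond the scatter)). Exchanging chloro for methoxy also raises the number (a 4.6-fold higher number from compound 1 to compound 4 (0.67 log units; beyond the scatter)), as does replacing the 4-chlorophenyl group with the 3-methoxyphenyl group (a 4.2-fold higher number from compound 2 to compound 4 (0.62 log units; beyond the scatter)), and both steps are modest. The two chlorophenyl compounds stay within the scatter of each other, so among these compounds the identity of the group matters more than where chloro sits on the phenyl ring.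

The compounds shown do not tell whether a 4-methoxyphenyl, 3-ethoxyphenyl or 3-hydroxyphenyl group would behave in the same way. No measurement at hand accounts for the rise.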